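Dinitrophenyl on the Amine Nitrogen of Compound 2

The compounds below may be only part of what the source reports. "The series", "measured", "known", "first", "only" and "open" are said of these compounds alone.

Of the compounds shown here, three sharing one core have been measured in a functional assay, read by spectrophotometry, with a stated time of 5 min; a lower number here means a stronger inhibitor, a higher number a weaker inhibitor. Compound 1 `O=c1cc(/C=N\c2ccccc2O)c2c(OCc3ccccc3)cc(OCc3ccccc3)cc2o1` gives 33100 nM. Compound 2 `N/N=C\c1cc(=O)oc2cc(OCc3ccccc3)cc(OCc3ccccc3)c12` gives 36500 nM. Compound 3 `O=c1cc(/C=N\c2ccc(O)cc2)c2c(OCc3ccccc3)cc(OCc3ccccc3)cc2o1` gives 249000 nM. Compound 2 thus stands second highest of the three numbers, with compound 1 nearest (a 1.1-fold higher number from compound 1 to compound 2 (0.04 log units; within the scatter), within the scatter) and compound 3 furthest (a 6.8-fold higher number from compound 2 to compound 3 (0.83 log units; beyond the scatter), beyond the scatter).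

Compound 4 `O=c1cc(/C=N\Nc2ccc([N+](=O)[O-])cc2[N+](=O)[O-])c2c(OCc3ccccc3)cc(OCc3ccccc3)cc2o1` differs from compound 2 by 2,4-dinitrophenyl in place of hydrogen on an amine nitrogen, that is, on the amine nitrogen whose other neighbour is the double-bonded nitrogen. Within the data shown here, no measured step touches this nitrogen directly. The measured steps alter the group on the double-bonded nitrogen: replacing 2-hydroxyphenyl by amino changed nothing beyond the scatter (a 1.1-fold higher number from compound 1 to compound 2 (0.04 log units; within the scatter)), whereas introducing 4-hydroxyphenyl in place of amino weakened inhibition (a 6.8-fold higher number from compound 2 to compound 3 (0.83 log units; beyond the scatter)), as did 4-hydroxyphenyl in place of 2-hydroxyphenyl (a 7.5-fold higher number from compound 1 to compound 3 (0.88 log units; beyond the scatter)). Adding an aryl group near this position has therefore been either neutral or modestly unfavourable. In this assay compound 4 is expected to show a step of a 1.6-fold higher number from compound 2 to compound 4 (0.22 log units; within the scatter), a modest weakening. Compound 4 is estimated at 60000 nM, within a range from 15000 nM to 240000 nM.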

Compound 4, half-maximal inhibitory concentration: 292000 nM
Compound 4: middle estimate off by 4.9-fold (0.69 log units), on the low side; measured number outside the range, above it.
By their numbers in this assay, from the lowest: compounds 1 and 2 (each within the scatter of the next); then compounds 3 and 4 (each within the scatter of the next).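

In this assay, among these compounds, the step of an 8.0-fold higher number from compound 2 to compound 4 (0.90 log units; beyond the scatter) is the first measured change on the amine nitrogen whose other neighbour is the double-bonded nitrogen, and it shows that this nitrogen does not tolerate every substituent without loss: 2,4-dinitrophenyl in place of hydrogen weakens inhibition beyond the scatter. The earlier steps shown here altered only the group on the double-bonded nitrogen, where one aryl exchange stayed within the scatter and the others did not, so they could say nothing about substitution on the amine nitrogen itself. The entering group brings 12 heavy atoms, one six-membered aromatic ring and no hydrogen-bond donors, but nothing given here ties the weakening to any one of these features or offers a measured explanation for it.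

With a single substituent on this nitrogen, the aromatic ring and its two nitro groups cannot be told apart as the source of the step. A plain phenyl or a methyl on the same amine nitrogen would show whether inhibition also weakens with other substituents there. It would also show whether a small group is tolerated.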